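An Acid Tail in Place of an Acetyl Group

This account rests on a few compounds, and the source may have more. Where it says the series, first, only, none or still open, it means among the compounds named here.

Compound 1 `COc1ccc(/C(=N/OC(C)=O)c2cccc3ccccc23)c(OC)c1OC`, compound 2 `COc1ccc(C(c2ccc(O)cc2)c2cccc3ccccc23)c(OC)c1OC` and compound 3 `COc1ccc(/C(=C\c2ccc(F)cc2)c2cccc3ccccc23)c(OC)c1OC` share a common core and were all tested in a functional assay on MCF7 cells (Homo sapiens) for inhibition, read by sulforhodamine B assay, with a stated time of 48 h; a higher number here means a weaker inhibitor, a lower number a stronger inhibitor. In this assay compound 1 gives only a limit, > 20000 nM, so no exact number is known for it; this is the limit of > 20000 nM in this assay, at which 1 of the 3 values shown sits. In this assay compound 2 gives 17500 nM and compound 3 gives 17700 nM, both weak inhibitors.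

Compound 4 `COc1ccc(/C(=N/OCC(=O)O)c2cccc3ccccc23)c(OC)c1OC` differs from compound 1 by carboxymethyl in place of acetyl on an oxygen. Within the data shown here, no measured pair shows what this change does, so the expectation rests on compound 1 alone, which already stands at the limit. The step that the limit leaves unreadable from compound 1 to compound 4 is expected to be small, staying within the usual scatter. Compound 4 is therefore estimated at 22000 nM, with a range from 8000 nM to 60000 nM.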

Compound 4, half-maximal inhibitory concentration: > 20000 nM
Compound 4: only a limit was reported; the forecaster's own chance of this, stated with the estimate: 60%; the middle value is on the limit's open side.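

Compound 1 and compound 4 each give only a limit, so no step between them can be read: the limit of > 20000 nM in this assay, at which 2 of the 4 values shown sit.

On these data alone, whether carboxymethyl in place of acetyl on an oxygen changes the inhibition at all stays open.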